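Swapping a Thiophene Alkyne for Methylamino

The source may hold more compounds than are shown below. What is called first, only, known or untested is meant among the compounds shown, and "the series" means these compounds.

Among the measured compounds shown here, compound 2 `CNC(=O)[C@@]12C[C@@H]1[C@@H](n1cnc3cnc(C#Cc4ccc(Cl)s4)nc31)[C@H](O)[C@@H]2O` gives the lower of the two numbers measured so far in an assay on CHO cells for displacement of a labelled ligand from transmembrane domain-containing protein TMIGD3 (Homo sapiens), read by scintillation counting, with a stated time of 60 min (a higher number here means a weaker inhibitor, a lower number a stronger inhibitor), with 60 nM; compound 1 `CNC(=O)[C@@]12C[C@@H]1[C@@H](n1cnc3c(OC)nc(C#Cc4ccc(Cl)s4)nc31)[C@H](O)[C@@H]2O` gives 684 nM, and an 11-fold lower number from compound 1 to compound 2 (1.06 log units; beyond the scatter). Compound 3 `CNC(=O)[C@@]12C[C@@H]1[C@@H](n1cnc3cnc(NC)nc31)[C@H](O)[C@@H]2O` is compound 2 after one change: methylamino in place of 2-(5-chlorothiophen-2-yl)ethynyl on an aromatic carbon. For the measured compounds named here, the only measured step altered a methoxy group at a different carbon, so no measured step bears directly on this exchange, and the expectation rests on the structural change alone. Compound 3 is expected to be a weaker binder, with the step of a 10-fold higher number from compound 2 to compound 3 (1.00 log units; beyond the scatter), and its estimated value is 600 nM with a range from 80 nM to 5000 nM.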

Compound 3, inhibition constant: 604 nM
For compound 3 the middle estimate is 1.0-fold (0.00 log units) below the measured one, and the stated range covers the measured number.
By their numbers in this assay, from the lowest: compound 2; then compounds 3 and 1 (each within the scatter of the next).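

In this assay, the carbon between two ring nitrogen atoms proves sensitive to what it carries, with a 10-fold higher number from compound 2 to compound 3 (1.00 log units; beyond the scatter) when 2-(5-chlorothiophen-2-yl)ethynyl gives way to methylamino. Even so, the far smaller group leaves compound 3 with a measurable 604 nM. No supporting data explain this difference.

Whether the chlorine, the thiophene ring or the triple bond accounts for the gap remains open. So does how dimethylamino or an unsubstituted phenylethynyl group would read at this carbon.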